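The source may report more compounds than this note shows. Statements on the series, on what has been measured and on what is new or still open speak of the compounds shown alone.

Compound 1 `Cc1nnsc1CO/N=C/c1c(C)nn(C)c1Oc1cccc(F)c1`: > 50000 nM; compound 2 `Cc1nnsc1CO/N=C/c1c(C)nn(C)c1Oc1cccc(F)c1F`: 6560 nM; compound 3 `Cc1nnsc1CO/N=C/c1c(C)nn(C)c1Oc1cc(F)cc(F)c1`: 8120 nM.

In a functional assay on HCT-116 cells (Homo sapiens) for inhibition, read by MTT assay, with a stated time of 48 h (on this read-out higher numbers stand for weaker inhibition and lower numbers for stronger inhibition), compound 1 gives > 50000 nM, which is a limit of the assay and not a number; it sits at the limit of > 50000 nM in this assay, at which 1 of the 3 values shown sits. Compound 2 gives 6560 nM and compound 3 gives 8120 nM, so that an at least 7.6-fold lower number from compound 1 to compound 2 (0.88 log units; beyond the scatter) and an at least 6.1-fold lower number from compound 1 to compound 3 (0.78 log units; beyond the scatter) both run toward stronger inhibition, whereas a 1.2-fold higher number from compound 2 to compound 3 (0.09 log units; within the scatter) stays flat. Compound 4 `Cc1nnsc1CO/N=C/c1c(C)nn(C)c1Cl` differs from compound 1 in that (chloro in place of 3-fluorophenoxy on an aromatic carbon). For the measured compounds named here, no measured step touches this change: each of them adds fluoro to the phenoxy ring rather than removing that ring, so nothing points to a step beyond the scatter in either direction. Compound 4 is expected near 45000 nM, between 8000 nM and 200000 nM, meaning an expected at least 1.1-fold lower number from compound 1 to compound 4 (0.04 log units; that floor lies within the scatter), with a fair chance that this assay again reports only a limit.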

Compound 4, half-maximal inhibitory concentration: > 50000 nM
Compound 4: no number, only a limit; the forecaster's own chance of this, stated with the estimate: 60%; middle value at least 1.1-fold (0.04 log units) from the limit.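

In this assay compound 4 gives > 50000 nM, which is a limit of the assay and not a number, and compound 1 also stands at a limit, so the step between them cannot be read. The compounds shown leave open whether chloro in place of 3-fluorophenoxy changes inhibition at all, and by how much.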